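From 4-Chlorophenyl to Butyl on the Ester Carbonyl

The source may report more compounds than this note shows. Statements on the series, on what has been measured and on what is new or still open speak of the compounds shown alone.

In a functional assay on CaEs17 cells (Homo sapiens) for inhibition, read by MTT assay (on this read-out lower numbers stand for stronger inhibition and higher numbers for weaker inhibition), compound 1 `C=C1C(=O)[C@@]23C(=O)OC[C@]4([C@@H](OC(C)=O)CCC(C)(C)[C@H]4C=O)[C@@H]2CC[C@H]1[C@H]3OC(=O)c1ccc(Cl)cc1` gives 1250 nM. Compound 2 `C=C1C(=O)[C@@]23C(=O)OC[C@]4([C@@H](OC(C)=O)CCC(C)(C)[C@H]4C=O)[C@@H]2CC[C@H]1[C@H]3OC(=O)c1ccc([N+](=O)[O-])cc1` gives 1600 nM, and the step of a 1.3-fold higher number from compound 1 to compound 2 (0.11 log units; within the scatter) lies within the scatter, so these two together hold the low end of the three numbers. Compound 3 `C=C1C(=O)[C@@]23C(=O)OC[C@]4([C@@H](OC(C)=O)CCC(C)(C)[C@H]4C=O)[C@@H]2CC[C@H]1[C@H]3OC(C)=O`, with methyl on the same carbonyl carbon, gives 2800 nM.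

Compound 4 `C=C1C(=O)[C@@]23C(=O)OC[C@]4([C@@H](OC(C)=O)CCC(C)(C)[C@H]4C=O)[C@@H]2CC[C@H]1[C@H]3OC(=O)CCCC` has not yet been measured. It carries butyl in place of 4-chlorophenyl on a carbonyl carbon, the carbon whose other neighbours are oxygen next to a carbonyl group (butyl in place of 4-chlorophenyl on a carbonyl carbon). Two measured steps change the group at this place. Replacing 4-chlorophenyl with methyl gives the modest step of a 2.2-fold higher number from compound 1 to compound 3 (0.35 log units; beyond the scatter), beyond the scatter, while replacing 4-nitrophenyl with methyl gives the step of a 1.8-fold higher number from compound 2 to compound 3 (0.24 log units; within the scatter), within it. For the measured compounds named here, no measured compound carries butyl, so the data do not show where butyl falls relative to methyl. A small rise is therefore expected in this assay, in the same direction as the move to compound 3 but probably no larger, and it may not clear the scatter. The expected change is the step of a 1.6-fold higher number from compound 1 to compound 4 (0.20 log units; within the scatter). For compound 4 the estimated value is 2000 nM, with an expected range of 1000 nM to 4000 nM.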

Compound 4, half-maximal inhibitory concentration: 2850 nM
Estimate against measurement, compound 4: 1.4-fold (0.15 log units) below; measured number inside the range.
By their numbers in this assay, from the lowest: compounds 1, 2, 3 and 4 (each within the scatter of the next, the first and the last beyond it).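

In this assay the butyl ester reads the same as the methyl ester (a 1.0-fold higher number from compound 3 to compound 4 (0.01 log units; within the scatter)), so propyl in place of hydrogen on the saturated chain carbon bound to the carbonyl carbon leaves the number unchanged within the scatter. Compound 1 now stands apart from two esters without a ring, since the modest step to butyl (a 2.3-fold higher number from compound 1 to compound 4 (0.36 log units; beyond the scatter)) matches in size the one already seen to methyl, but compound 2 goes against any general separation of aromatic from chain esters (a 1.8-fold higher number from compound 2 to compound 4 (0.25 log units; within the scatter)), as this step stays within the scatter, as its step to compound 3 did. No measurement at hand accounts for this pattern.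

The compounds shown leave open whether the separation of compound 1 belongs to the aromatic ring or to its chlorine, a question that an unsubstituted phenyl ester would address. They also leave open whether the flat reading from methyl to butyl holds for a longer chain such as octyl, or for a chain ending in an amine or a carboxylic acid.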